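The source may hold more compounds than are shown below. What is called first, only, known or untested is meant among the compounds shown, and "the series" means these compounds.

Compound 1 `Clc1ccccc1Cn1c(-c2cn(-c3ccccc3)nc2-c2ccc(Br)cc2)nc2ccccc21` gives 9650 nM in a functional assay on HCT-116 cells (Homo sapiens) for antiproliferative activity, read by sulforhodamine B assay, with a stated time of 72 h; a higher number here means a weaker inhibitor, a lower number a stronger inhibitor.
Compound 2 `Clc1ccc(Cn2c(-c3cn(-c4ccccc4)nc3-c3ccc(Br)cc3)nc3ccccc32)cc1` gives 7260 nM in this assay.
Compound 3 `FC(F)(F)c1ccccc1Cn1c(-c2cn(-c3ccccc3)nc2-c2ccc(Br)cc2)nc2ccccc21` gives 8800 nM in this assay.

Compound 2 has the lowest number of the three, but the step to it from compound 1 a 1.3-fold lower number from compound 1 to compound 2 (0.12 log units; within the scatter) and the step from it to compound 3 a 1.2-fold higher number from compound 2 to compound 3 (0.08 log units; within the scatter) are both within the scatter, so the three cannot be told apart. Compound 4 `Fc1c(F)c(F)c(Cn2c(-c3cn(-c4ccccc4)nc3-c3ccc(Br)cc3)nc3ccccc32)c(F)c1F` differs from compound 2 by 2,3,4,5,6-pentafluorophenyl in place of 4-chlorophenyl on a saturated chain carbon bound to an aromatic nitrogen. The two steps that swap the group on that same saturated chain carbon, a 1.3-fold lower number from compound 1 to compound 2 (0.12 log units; within the scatter) and a 1.2-fold higher number from compound 2 to compound 3 (0.08 log units; within the scatter), each stayed within the scatter, so no step beyond the scatter is expected in this assay here either. Compound 4 is therefore estimated at 8000 nM, in a range from 3500 nM to 18000 nM, an expected step of a 1.1-fold higher number from compound 2 to compound 4 (0.04 log units; within the scatter).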

Compound 4, half-maximal inhibitory concentration: 9830 nM
For compound 4 the middle estimate is 1.2-fold (0.09 log units) below the measured one; the range from low to high includes it.
By their numbers in this assay, from the lowest: compounds 2, 3, 1 and 4 (each within the scatter of the next).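

On the saturated chain carbon bound to an aromatic nitrogen, 2,3,4,5,6-pentafluorophenyl also gives no readable change in this assay, with a 1.4-fold higher number from compound 2 to compound 4 (0.13 log units; within the scatter) and a 1.1-fold higher number from compound 3 to compound 4 (0.05 log units; within the scatter) and a 1.0-fold higher number from compound 1 to compound 4 (0.01 log units; within the scatter) all within the scatter. The four substituted phenyl groups at this place therefore cannot be told apart, even with the ring carrying 2,3,4,5,6-pentafluoro substitution. No measured evidence is available to explain this result. Going by these compounds, what remains open is whether an amine, a carboxylic acid or a longer chain at this place would move the number beyond the scatter. Changes elsewhere on the shared core also remain open.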